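Methylsulfonyl on the amide-type nitrogen: an expected step

The source may hold more compounds than are shown below. What is called first, only, known or untested is meant among the compounds shown, and "the series" means these compounds.

Measured compounds:
compound 1, `Cc1n[nH]c(C(N)=O)c1Cc1cccc(-c2ccc(F)cc2)c1`, gives 1%
compound 2, `CNC(=O)c1[nH]nc(C)c1Cc1cccc(-c2ccc(F)cc2)c1`, gives 7%
compound 3, `Cc1n[nH]c(C(=O)O)c1Cc1cccc(-c2ccc(C(=O)O)cc2)c1`, gives 3%

All three were measured in an assay on isolated protein for inhibition of 2-Hydroxyacid oxidase 2 (Homo sapiens), tested at 1 uM; a higher number here means a stronger effect of the compound at the concentration tested, a lower number a weaker effect. Compound 2 has the highest of the three numbers, yet its gap to compound 3 and its gap to compound 1 both lie within the scatter, so no order among the three can be read from them. Going by the values given here, the single step that can be traced between two measured compounds, a number 6 percentage points higher from compound 1 to compound 2 (within the scatter), also lies within the scatter.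

Compound 4, `Cc1n[nH]c(C(=O)NS(C)(=O)=O)c1Cc1cccc(-c2ccc(F)cc2)c1`, differs from compound 2 by methylsulfonyl in place of methyl on an amide-type nitrogen. Among the compounds with values here, no measured pair bears directly on this change. Within the data shown here, the only measured step concerns the same amide-type nitrogen, but there hydrogen gave way to methyl, and it produced nothing beyond the scatter. The measured compounds therefore give no ground for expecting a step beyond the scatter, and the estimated step of no change at the digits printed from compound 2 to compound 4 (within the scatter) is one of no real size. Compound 4 is expected to give 7%, with a range from -5% to 20%.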

Compound 4, a percentage reported as inhibition, at one concentration (the size of the read-out at that concentration, not a potency): 8%
Compound 4: the middle estimate sits 1 percentage points below what was measured, within the range that was stated.
By their numbers in this assay, from the lowest: compounds 1, 3, 2 and 4 (each within the scatter of the next).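

Methylsulfonyl in place of methyl on the amide-type nitrogen gives a number 1 percentage points higher from compound 2 to compound 4 (within the scatter) in this assay, and methylsulfonyl in place of hydrogen at the same nitrogen gives a number 7 percentage points higher from compound 1 to compound 4 (within the scatter) on the same core. Going by these compounds alone, with hydrogen, methyl and methylsulfonyl all tried at this position, no step among them leaves the scatter, so this much larger group, with its sulfur and its oxygens, can be told apart from neither of the smaller ones at the concentration tested. No supporting measurement bears on this result.

Going by these compounds, whether anything placed on this nitrogen can move the number beyond the scatter remains open, for instance an aminoethyl group, a longer alkyl chain or phenylsulfonyl in place of methylsulfonyl. A reading at one concentration also leaves open whether these compounds would differ at higher concentrations.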